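A few compounds are considered here, and "the series" means these few. Any claim that something is new, unique, unknown or untested is made for them only; others in the source may bear on it.

Among the compounds with values here, in an ADME assay on the whole organism (Mus musculus, strain CD1) for pharmacokinetics, read by LC-MS, with a stated time of 24 h, at a dose of 5 mg/kg by the oral route (a lower number here means less compound in the circulation, a higher number more compound in the circulation at the dose given), compound 2 (`CCOc1cc2[nH]c(Cc3nn(CC(=O)O)c(=O)c4ccccc34)nc2cc1Cl`) gives 361000 nM, the higher of the two numbers so far, while compound 1 (`O=C(O)Cn1nc(Cc2nc3cc(Cl)c(OCC(F)F)cc3[nH]2)c2ccccc2c1=O`) gives 82400 nM. Compound 3 (`O=C(O)Cn1nc(Cc2nc3cc(Cl)c(OCC4CC4)cc3[nH]2)c2ccccc2c1=O`) has not yet been measured. It carries cyclopropyl in place of methyl on a saturated chain carbon bound to an oxygen on an aromatic ring, which turns ethoxy into cyclopropylmethoxy (cyclopropyl in place of methyl on a saturated chain carbon bound to an oxygen on an aromatic ring). Within the data shown here, only one measured step bears on this place: a 4.4-fold higher number from compound 1 to compound 2 (0.64 log units; beyond the scatter), a modest change for methyl in place of difluoromethyl. It shows that a change at this carbon can move the number, but it says nothing about cyclopropyl itself. On the strength of that single step, and with compound 2 holding the higher value, a downward step of similar or smaller size is expected in this assay. The estimated step is a 2.3-fold lower number from compound 2 to compound 3 (0.35 log units; beyond the scatter). For compound 3 the expected value is 160000 nM, with an estimated range of 55000 nM to 420000 nM.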

Compound 3, maximal plasma concentration in the Mus musculus assay: 98000 nM
For compound 3 the middle estimate is 1.6-fold (0.21 log units) above the measured one, and the stated range covers the measured number.
By their numbers in the Mus musculus assay, from the lowest: compounds 1 and 3 (each within the scatter of the next); then compound 2.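

In the Mus musculus assay, cyclopropyl in place of methyl at this carbon gives a 3.7-fold lower number from compound 2 to compound 3 (0.57 log units; beyond the scatter), so a second group, besides difluoromethyl, now stands apart from methyl. The step between those two groups reads a 1.2-fold higher number from compound 1 to compound 3 (0.08 log units; within the scatter), which puts compound 1 and compound 3 within the scatter of each other and leaves the ethoxy of compound 2 alone at the top of the three. In a physicochemical assay for lipophilicity, at pH 7.4 (a lower number here means a more polar compound, a higher number a more lipophilic compound), compound 2 gives 1.8 and compound 3 gives 2.21, and the change from methyl to cyclopropyl also goes with a more lipophilic compound: the measured distribution coefficient of compound 2, 1.8, and of compound 3, 2.21, a number 0.41 log units higher (beyond the scatter)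

Going by these compounds, whether a propyl chain, or a hydroxyl or an amine on this chain, would keep the number of compound 2 remains open. A single pair also cannot tell whether the number in the Mus musculus assay follows the distribution coefficient across this position.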